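Trifluoromethyl for Fluoro on a Benzofuran Sulfonamide Series

This account rests on a few compounds, and the source may have more. Where it says the series, first, only, none or still open, it means among the compounds named here.

Of the compounds shown here, three share a core and have been tested in a functional assay on HCT-116 cells (Homo sapiens) for inhibition, read by MTT assay, with a stated time of 72 h; on this read-out higher numbers stand for weaker inhibition and lower numbers for stronger inhibition. Compound 1 `CCOC(=O)c1oc2ccc(NS(=O)(=O)c3ccc(C(F)(F)F)cc3)cc2c1C` and compound 2 `CCOC(=O)c1oc2ccc(NS(=O)(=O)c3ccc(F)cc3)cc2c1C` differ in one place: trifluoromethyl in place of fluoro on an aromatic carbon. In this assay compound 1 gives 24200 nM. For compound 2 this assay reports only a limit, > 40000 nM. That gives an at least 1.6-fold lower number from compound 2 to compound 1 (0.21 log units; that floor lies within the scatter). For compound 3 `Cc1c(C(=O)O)oc2ccc(N(Cc3ccccc3)S(=O)(=O)c3ccc(F)cc3)cc12` this assay again reports only a limit, > 40000 nM. How the core of compound 3 differs from the core of compound 2 is not broken down here.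

Compound 4 `Cc1c(C(=O)O)oc2ccc(N(Cc3ccccc3)S(=O)(=O)c3ccc(C(F)(F)F)cc3)cc12` has not yet been measured. It differs from compound 3 by trifluoromethyl in place of fluoro on an aromatic carbon. Among the compounds with values here, this is the same kind of change as the one from compound 2 to compound 1; the place is described in the same words, an aromatic carbon of a six-membered aromatic ring of carbon only, para to a large group, with the added reading that, cut one bond further out, it is 4-fluorophenyl to 4-(trifluoromethyl)phenyl. The earlier step was at least a modest lowering whose floor lies within the scatter, and the starting value of compound 3 is a limit, so compound 4 is expected to sit near that limit, with a chance of falling just under it, a step estimated at an at least 1.1-fold lower number from compound 3 to compound 4 (0.05 log units; that floor lies within the scatter), resting on (the limit of > 40000 nM in this assay, at which 2 of the 3 values shown sit). The estimate for compound 4 in this assay is 35000 nM, expected to lie between 15000 nM and 80000 nM.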

Compound 4, half-maximal inhibitory concentration: 21100 nM
Compound 4: the middle estimate sits 1.7-fold (0.22 log units) above what was measured, within the range that was stated.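

Replacing fluoro with trifluoromethyl on the aromatic carbon gives, in this assay, an at least 1.8-fold lower number from compound 3 to compound 4 (0.27 log units; that floor lies within the scatter), and the same change on the other core gives an at least 1.6-fold lower number from compound 2 to compound 1 (0.21 log units; that floor lies within the scatter). Both steps point toward a lower number, although each floor lies within the usual scatter, and setting them side by side gives this reading: the same change on two cores in this assay, an at least 1.6-fold lower number (0.21 log units; that floor lies within the scatter) from compound 2 to compound 1 and an at least 1.8-fold lower number (0.27 log units; that floor lies within the scatter) from compound 3 to compound 4; the limit leaves it open whether they differ. Compound 2 and compound 3 are known only as limits, which leaves both steps without a true size and shows neither an equal effect on the two cores nor a lowering beyond the scatter: the limit of > 40000 nM in this assay, at which 2 of the 4 values shown sit.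

The compounds shown carry only fluoro or trifluoromethyl at this place, and whether a nitrile, a methoxy group or a chlorine atom there would also give a lower number remains open. Also open, from the compounds shown here alone, is how far the change carries to cores beyond these two, for example one with an amide in place of the ester of compound 1 or the carboxylic acid of compound 4, and what a change to the core does on its own.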